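Replacing One Piperidinyl Group with Ethyl

The source may hold more compounds than are shown below. What is called first, only, known or untested is meant among the compounds shown, and "the series" means these compounds.

Measured compounds:
compound 1 `Cc1cc(C2CCCCC2)c(S(C)(=O)=O)cc1C(=O)N=C(N)N`, 22 nM
compound 2 `CCc1cc(OC)c(S(C)(=O)=O)cc1C(=O)N=C(N)N`, 30 nM
compound 3 `CS(=O)(=O)c1cc(C(=O)N=C(N)N)c(N2CCCCC2)cc1N1CCCCC1`, 1000 nM

In a functional assay for inhibition of sodium/hydrogen exchanger (Oryctolagus cuniculus) (a higher number here means a weaker inhibitor, a lower number a stronger inhibitor), compound 3 gives the highest number of the three, so it is the weakest inhibitor shown; compound 2 sits nearest, compound 1 furthest, and both gaps lie beyond the scatter. Compound 4 `CCc1cc(N2CCCCC2)c(S(C)(=O)=O)cc1C(=O)N=C(N)N` differs from compound 3 in one place: ethyl in place of piperidin-1-yl on an aromatic carbon. Among the measured compounds shown here, no measured pair shows this exact change, but compounds 1 and 2, which carry small groups at that position, both give low numbers. Compound 4 is therefore expected to move strongly downward, a step of a 17-fold lower number from compound 3 to compound 4 (1.22 log units; beyond the scatter). Compound 4 is estimated at 60 nM, within a range of 15 nM to 250 nM.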

Compound 4, half-maximal inhibitory concentration: 25 nM
Compound 4: middle estimate off by 2.4-fold (0.38 log units), on the high side; the range from low to high includes it.
By their numbers in this assay, from the lowest: compounds 1, 4 and 2 (each within the scatter of the next); then compound 3.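

Ethyl in place of piperidin-1-yl on the aromatic carbon para to the methylsulfonyl group gives a 40-fold lower number from compound 3 to compound 4 (1.60 log units; beyond the scatter) in this assay, so this single change is enough to produce a large difference. Compound 4 keeps a piperidin-1-yl group at the other site, and piperidin-1-yl in place of methoxy there gives a 1.2-fold lower number from compound 2 to compound 4 (0.08 log units; within the scatter), so these two groups cannot be told apart in this measurement. Nothing shown explains either result. On these data alone, it remains open whether a propyl chain or an amine at the ethyl-bearing carbon would also give a low number.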